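Pyrimidin-5-yl for 2-methylpyridin-3-yl on the ring nitrogen

The compounds below may be only part of what the source reports. "The series", "measured", "known", "first", "only" and "open" are said of these compounds alone.

Measured compounds:
compound 1 `Cc1cccc(-c2ccc(NC[C@H]3CC[C@]4(CC3)CN(c3cccnn3)C(=O)O4)nc2)n1` — in a functional assay for antagonist activity at Neuropeptide Y receptor type 5 (Homo sapiens) (on this read-out higher numbers stand for weaker inhibition and lower numbers for stronger inhibition), compound 1 gives 0.251 nM
compound 2 `Cc1ncccc1N1C[C@]2(CC[C@@H](CNc3cnn(-c4ccccc4F)c3)CC2)OC1=O` — compound 2 gives 0.631 nM
compound 3 `O=C1O[C@]2(CC[C@H](CNc3ccc(-c4cc(F)cc(F)c4)nn3)CC2)CN1c1cccnn1` — compound 3 gives 0.1 nM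

Compound 2 stands at the highest number of the three in this assay; compound 1 lies lower, beyond the scatter, and compound 3 lower still, also beyond the scatter. Compound 4 `O=C1O[C@]2(CC[C@H](CNc3cnn(-c4ccccc4F)c3)CC2)CN1c1cncnc1` differs from compound 2 by pyrimidin-5-yl in place of 2-methylpyridin-3-yl on an amide-type nitrogen in a ring. Going by the values given here, no measured pair covers this change in isolation; the measured compounds differ from one another in several places at once, so no step size can be read from them. The expectation is a small shift, a 1.3-fold lower number from compound 2 to compound 4 (0.10 log units; within the scatter), with no change beyond the scatter as the central case. For compound 4 the estimated value in this assay is 0.5 nM, within a range from 0.15 nM to 2 nM.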

Compound 4, inhibition constant: 0.0398 nM
Compound 4: the middle estimate sits 13-fold (1.10 log units) above what was measured, outside the stated range (below it).
By their numbers in this assay, from the lowest: compound 4; then compound 3; then compound 1; then compound 2.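

In this assay, going by these compounds alone, the position on the amide-type nitrogen in a ring proves sensitive to the group it carries: pyrimidin-5-yl in place of 2-methylpyridin-3-yl gives a 16-fold lower number from compound 2 to compound 4 (1.20 log units; beyond the scatter), the first step that can be read for one place. This single change both removes the methyl group and replaces a ring with 1 hetero atom by one with 2. Nothing measured here accounts for the size of the step.

Which of these two differences carries the step remains open; unsubstituted pyridin-3-yl and 2-methylpyrimidin-5-yl would separate them.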